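The source may hold more compounds than are shown below. What is called first, only, known or untested is meant among the compounds shown, and "the series" means these compounds.

Measured so far:
- compound 1 `CCCCn1cnc2c(NCc3ccc(C(=O)Nc4ccccc4N)cc3)nc(Cl)nc21`: 100 nM
- compound 2 `Nc1nc(NCc2ccc(C(=O)Nc3ccccc3N)cc2)nc(NC2CCCC2)n1`: 700 nM

Both compounds were read in a functional assay on HCT-116 cells (Homo sapiens) for cytotoxicity, read by MTT assay; on this read-out lower numbers stand for stronger inhibition and higher numbers for weaker inhibition. Compound 2 gives 700 nM, the higher of the two numbers, and compound 1 stands lower at 100 nM, a gap beyond the usual scatter. Within the data shown here, the two compounds differ in more than one place, so this gap says nothing about any single group, and no measured one-place step is available as a guide.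

The next compound is compound 3 `Nc1nc(NCc2ccc(C(=O)Nc3ccccc3N)cc2)nc(N2CCc3ccccc32)n1`, which carries 2,3-dihydro-1H-indol-1-yl in place of cyclopentylamino on an aromatic carbon. The rest of compound 2 is kept. Among the measured compounds shown here, with no measured precedent for this exchange, the only anchor is compound 2 at 700 nM. For the measured compounds named here, no step clearly beyond the scatter is expected in this assay, with only a slight lean towards a lower number. The expected change is a 1.8-fold lower number from compound 2 to compound 3 (0.24 log units; within the scatter). The estimated value for compound 3 is 400 nM, with an expected range from 100 nM to 1500 nM.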

Compound 3, half-maximal inhibitory concentration: 800 nM
Compound 3: middle estimate off by 2.0-fold (0.30 log units), on the low side; low and high end bracket the measured number.
By their numbers in this assay, from the lowest: compound 1; then compounds 2 and 3 (each within the scatter of the next).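

In this assay, among these compounds, placing 2,3-dihydro-1H-indol-1-yl instead of cyclopentylamino on the aromatic carbon between two ring nitrogen atoms gives a 1.1-fold higher number from compound 2 to compound 3 (0.06 log units; within the scatter), so this change produces no step that can be told from the scatter. The entering group has more heavy atoms, adds a six-membered aromatic ring of carbon only and has no hydrogen-bond donor where cyclopentylamino has one, yet in this single pair these differences together leave the read-out without a clear step. Nothing measured here speaks to the reason for this flat step.

Compound 2 and compound 3 each differ from compound 1 in more than one place, so the lower number of compound 1, 100 nM, cannot be tied to any single group. On these data alone, it remains open whether an open-chain amine such as butylamino or a ring amine such as morpholine on this carbon would move the number beyond the scatter, and what replacing the amino group kept in compound 2 and compound 3 with a chlorine atom would do.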